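The source may report more compounds than this note shows. Statements on the series, on what has been measured and on what is new or still open speak of the compounds shown alone.

Compound 1 `COc1ccc(-c2cc(/C=C/C(=O)c3ccc(N)cc3)[nH]n2)cc1`, compound 2 `COc1ccc(-c2cc(/C=C/C(=O)c3ccc(N)cc3)[nH]n2)cc1OC` and compound 3 `COc1cc(C(=O)/C=C/c2cc(-c3cc(OC)c(OC)c(OC)c3)n[nH]2)cc(OC)c1OC` share a core and were all tested in a functional assay on CCRF-CEM cells (Homo sapiens) for cytotoxicity, read by sulforhodamine B assay, with a stated time of 48 h, tested at 0.01 uM; a lower number here means a stronger effect, a higher number a weaker effect of the compound at the concentration tested. In this assay compound 1 gives 99%, compound 2 gives 97% and compound 3 gives 96%, so all three sit within the scatter of one another. From compound 2 to compound 1 the change is hydrogen in place of methoxy on an aromatic carbon, and its step is a number 2 percentage points higher from compound 2 to compound 1 (within the scatter). How the cores of compound 2 and compound 3 differ is not broken down here. Compound 4 `COc1ccc(-c2cc(/C=C/C(=O)c3cc(OC)c(OC)c(OC)c3)[nH]n2)cc1OC` has not been measured yet; it arises from compound 3 by the same kind of change, (hydrogen in place of methoxy on an aromatic carbon), the place now also lying meta to a methoxy group. Because the earlier step of a number 2 percentage points higher from compound 2 to compound 1 (within the scatter) stayed within the scatter, a similarly small step is expected: a number 1 percentage points higher from compound 3 to compound 4 (within the scatter). Compound 4 is therefore estimated to give 97% in this assay, likely between 90% and 100%.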

Compound 4, a percentage reported as activity, at one concentration (the size of the read-out at that concentration, not a potency): 97%
Compound 4: middle estimate and measured number agree at the digits printed; low and high end bracket the measured number.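

In this assay the swap of methoxy for hydrogen on an aromatic carbon gives a small step, a number 1 percentage points higher from compound 3 to compound 4 (within the scatter), and it matches the earlier step on the other core: the same change on two cores in this assay, a number 2 percentage points higher (within the scatter) from compound 2 to compound 1 and a number 1 percentage points higher (within the scatter) from compound 3 to compound 4, 1 percentage points apart, within the scatter of two such steps. So, on these two cores, the change carries over with no difference that can be told from the scatter. This does not show that it would carry over to other cores, or at other concentrations, since neither step rises above the scatter and a single concentration cannot reveal any difference that might appear elsewhere.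

The compounds shown leave open what other groups would do in the same place. A hydroxyl group, a fluorine atom or a longer chain such as ethoxy could each be tried there in place of methoxy.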